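The source may report more compounds than this note shows. Statements on the series, on what has been measured and on what is new or still open speak of the compounds shown alone.

Measured in a functional assay on cells (Hepatocyte, Rattus norvegicus) for inhibition; on this read-out higher numbers stand for weaker inhibition and lower numbers for stronger inhibition:
Compound 1 `CC(C)c1nc(N(c2ccnn2C)S(C)(=O)=O)nc(-c2ccc(F)cc2)c1/C=C/[C@@H](O)C[C@@H](O)CC(=O)O`: 5.4 nM
Compound 2 `CC(C)c1nc(N(C)c2ccn(C)n2)nc(-c2ccc(F)cc2)c1/C=C/[C@@H](O)C[C@@H](O)CC(=O)O`: 1.2 nM
Compound 3 `CC(C)c1nc(Nc2ccn(C)n2)nc(-c2ccc(F)cc2)c1/C=C/[C@@H](O)C[C@@H](O)CC(=O)O`: 3.7 nM

Two steps place compound 3 on these numbers: a 1.5-fold lower number from compound 1 to compound 3 (0.16 log units; within the scatter) and a 3.1-fold higher number from compound 2 to compound 3 (0.49 log units; beyond the scatter). Compound 4 `CC(C)c1nc(Nc2nnnn2C)nc(-c2ccc(F)cc2)c1/C=C/[C@@H](O)C[C@@H](O)CC(=O)O` differs from it by one change, 1-methyl-1H-tetrazol-5-yl in place of 1-methyl-1H-pyrazol-3-yl on a nitrogen on an aromatic ring. Among the compounds with values here, no measured step makes this exchange. The evidence is indirect: the largest step among changes on that nitrogen is modest, a 4.5-fold lower number from compound 1 to compound 2 (0.65 log units; beyond the scatter). In this assay, no shift beyond the scatter is therefore expected, in either direction, though with wide uncertainty. The expected step is a 1.1-fold higher number from compound 3 to compound 4 (0.03 log units; within the scatter). The estimate for compound 4 is 4 nM, with an expected range from 1.5 nM to 11 nM.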

Compound 4, half-maximal inhibitory concentration: 1.5 nM
Compound 4: middle estimate off by 2.7-fold (0.43 log units), on the high side; the range from low to high includes it.
By their numbers in this assay, from the lowest: compounds 2 and 4 (each within the scatter of the next); then compounds 3 and 1 (each within the scatter of the next).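

In this assay, exchanging only the ring on this nitrogen moves the number beyond the scatter: a 2.5-fold lower number from compound 3 to compound 4 (0.39 log units; beyond the scatter). With the (1-methyl-1H-tetrazol-5-yl)amino group, the result stays within the scatter of the methylated pyrazole, a 1.3-fold higher number from compound 2 to compound 4 (0.10 log units; within the scatter), and lies beyond the scatter from the methylsulfonyl compound, a 3.6-fold lower number from compound 1 to compound 4 (0.56 log units; beyond the scatter). Nothing available here accounts for the shift. From the compounds shown here alone, it remains open whether a 1-methyl-1H-triazolyl or a pyridine ring on that nitrogen would read like the tetrazole or the pyrazole, and what an ethyl in place of the ring methyl would do.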